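Compound 3 to compound 4: one group exchanged

The source may hold more compounds than are shown below. What is called first, only, known or untested is meant among the compounds shown, and "the series" means these compounds.

Among the measured compounds shown here, in an ADME assay on MRC5 cells (Homo sapiens) for antiproliferative activity, read by fluorescence and resazurin assay, with a stated time of 68 h (on this read-out lower numbers stand for an effect already at smaller amounts and higher numbers for an effect only at larger amounts of compound), compound 1 `CN1CCN(c2cc(C(=O)NCCN3CCCC3)c3cc(F)ccc3n2)CC1` gives 20000 nM as the only true number so far. Compound 2 `O=C(NCCN1CCCC1)c1cc(N2CCn3ccnc3C2)nc2ccc(F)cc12` reads > 50000 nM and this is a limit of the assay. Compound 3 `O=C(NCCN1CCCC1)c1cc(NCCC2CCOCC2)nc2ccc(F)cc12` reads > 50000 nM and this too is a limit and not a number. That leaves compound 3 at the limit of > 50000 nM in this assay, at which 2 of the 3 values shown sit, with no measured number of its own.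

Compound 4 `CN(C)c1ccc(-c2cc(C(=O)NCCN3CCCC3)c3cc(F)ccc3n2)cc1` differs from compound 3 by 4-(dimethylamino)phenyl in place of (2-(oxan-4-yl)ethyl)amino on an aromatic carbon on the same carbon of the shared core. Two measured exchanges on this carbon bear on it: an at least 2.5-fold higher number from compound 1 to compound 2 (0.39 log units; beyond the scatter) and an at least 2.5-fold higher number from compound 1 to compound 3 (0.39 log units; beyond the scatter) are each at least modest. The third exchange is a step that the two limits leave unreadable from compound 2 to compound 3 and adds no size.

For the measured compounds named here, the group on this carbon therefore matters, yet compound 4 keeps neither group of the earlier compounds. Compound 1 at 20000 nM shows that a number can be reached with this core, so a modest move toward smaller numbers is expected. Staying at the limit remains possible. The expected step is an at least 2.0-fold lower number from compound 3 to compound 4 (0.30 log units; that floor lies within the scatter) in this assay and it remains uncertain. Compound 4 is estimated at 25000 nM with 8000 nM to 60000 nM as the expected range.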

Compound 4, half-maximal effective concentration: 10000 nM
The estimate for compound 4 lay 2.5-fold (0.40 log units) above the measured number; measured number inside the range.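

In this assay, 4-(dimethylamino)phenyl on the carbon next to the ring nitrogen gives a true number, with an at least 5.0-fold lower number from compound 3 to compound 4 (0.69 log units; beyond the scatter) and an at least 5.0-fold lower number from compound 2 to compound 4 (0.69 log units; beyond the scatter). Both steps are only floors, as compound 2 and compound 3 each stand at a limit and not at a number: the limit of > 50000 nM in this assay, at which 2 of the 4 values shown sit. Against 4-methylpiperazin-1-yl there is a 2.0-fold lower number from compound 1 to compound 4 (0.30 log units; within the scatter), so these two groups cannot be told apart on this read-out, and the two compounds with true numbers carry very different groups on this carbon.

From the compounds shown here alone, whether the step needs the dimethylamino group or only the ring of carbon stays open, and a plain phenyl group on the same carbon would help to separate the two. All the compounds shown also keep the (2-(pyrrolidin-1-yl)ethyl)carbamoyl group, so the effect of a shorter chain or a carboxylic acid in its place remains unknown.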